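A few compounds are considered here, and "the series" means these few. Any claim that something is new, unique, unknown or untested is made for them only; others in the source may bear on it.

Compound 1, `C=CC(=C)CC[C@@H]1[C@@]2(C)CCC[C@](C)(COC(=O)/C=C/c3ccc(O)c(OC)c3)[C@@H]2CC[C@@]1(C)O`, gives in a functional assay on A549 cells (Homo sapiens) for cytotoxicity, read by MTT assay, with a stated time of 48 h (a lower number here means a stronger inhibitor, a higher number a weaker inhibitor), a value of 16800 nM.
Compound 2, `C=CC(=C)[C@@H](O)C[C@H]1C(=C)CC[C@@H]2[C@]1(C)CCC[C@]2(C)C(=O)O`, reaches only a limit of the assay in this assay, > 40000 nM.
Compound 3, `C=C1CC[C@@H]2[C@](C)(CCC[C@@]2(C)C(=O)O)[C@H]1CC/C(C)=C/COC(C)=O`, also reaches only a limit in this assay, > 40000 nM.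

Among these three, compound 2 is not a number at all but a limit, meaning the assay could not resolve a value for it; the same holds for compound 3, so that (the limit of > 40000 nM in this assay, at which 2 of the 3 values shown sit). Only compound 1 stands at a resolved value, and it is a weak one.

Compound 4, `C=C1CC[C@@H]2[C@](C)(CCC[C@]2(C)C(=O)O)[C@H]1C/C=C(\C)C=O`, has not yet been tested in this assay. Compared with compound 2 the change is a group of 5 heavy atoms (4 carbon, 1 oxygen; no ring) in place of a group of 6 heavy atoms (5 carbon, 1 oxygen; no ring), on a saturated chain carbon bound to a saturated ring carbon, where a 2-formylprop-1-en-1-yl group enters on a saturated chain carbon bound to a saturated ring carbon. Within the data shown here, no measured pair in this set shows what such a change does. With compound 2 only at a limit, the step from compound 2 to compound 4 is expected to stay within the usual scatter, so that an at least 1.1-fold lower number from compound 2 to compound 4 (0.05 log units; that floor lies within the scatter) is the estimate. For compound 4 the expected result in this assay is 35000 nM, with a likely range from 12000 nM to 90000 nM, and a fair chance that only a limit is again reported.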

Compound 4, half-maximal inhibitory concentration: > 40000 nM
Compound 4 ended at the assay's limit; the forecaster's own chance of this, stated with the estimate: 50%; at least 1.1-fold (0.05 log units) between middle value and limit.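

Compound 2 and compound 4 both stand at a limit of this assay rather than at a number, so no step between them can be read: the limit of > 40000 nM in this assay, at which 3 of the 4 values shown sit.

Left open is whether the 2-formylprop-1-en-1-yl group of compound 4, in place of the group carried by compound 2, changes the result at all.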